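Swapping the Indolyl Arm for a Chlorophenyl Group

A few compounds are considered here, and "the series" means these few. Any claim that something is new, unique, unknown or untested is made for them only; others in the source may bear on it.

The compounds share one core, and the group attached to a saturated chain carbon bound to an amine nitrogen in a ring is what changes between them. In an in vitro functional assay on RBL cells for antagonist activity at C-C chemokine receptor type 8 (Homo sapiens), read by FLIPR and calcium flux (on this read-out lower numbers stand for stronger inhibition and higher numbers for weaker inhibition), compound 1 `COc1ccc2nccc(C3CN(C4CCCCN(Cc5cc6ccccc6[nH]5)C4)C(=O)O3)c2c1` gives < 50200 nM, which is a limit of the assay and not a number, namely (the limit of < 50200 nM in this assay, at which 1 of the 2 values shown sits). Among the compounds with values here, compound 2 `COc1ccc2nccc(C3CN(C4CCN(Cc5cc6ccccc6n5C)CC4)C(=O)O3)c2c1` is the only member with a measured number: in this assay compound 2 gives 3160 nM. Within the data shown here, the one further value in view is the limit of compound 1 named just before. Among the measured compounds shown here, no two measured compounds differ in a single place, so no measured step is available to guide the direction. Compound 3 `COc1ccc2nccc(C3CN(C4CCN(Cc5cccc(Cl)c5)CC4)C(=O)O3)c2c1` has not yet been measured. It differs from compound 2 by 3-chlorophenyl in place of 1-methyl-1H-indol-2-yl on a saturated chain carbon bound to an amine nitrogen in a ring. The step is expected to read a 1.6-fold higher number from compound 2 to compound 3 (0.20 log units; within the scatter), a shift toward weaker inhibition that is expected to stay close to the usual scatter rather than clearly beyond it. Compound 3 is therefore estimated at 5000 nM in this assay, with a range from 1000 nM to 25000 nM.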

Compound 3, half-maximal inhibitory concentration: 6310 nM
Compound 3: the middle estimate sits 1.3-fold (0.10 log units) below what was measured; measured number inside the range.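

In this assay, within the data shown here, compound 2 and compound 3 are the first pair that differ in a single place, and the pair gives a 2.0-fold higher number from compound 2 to compound 3 (0.30 log units; within the scatter). Among these compounds, at this place, on a saturated chain carbon bound to an amine nitrogen in a ring, the two values cannot be told apart, although 1-methyl-1H-indol-2-yl has a five-membered aromatic ring with 1 hetero atom and 3-chlorophenyl has only one six-membered aromatic ring of carbon only, with 0 hydrogen-bond acceptors. The five-membered ring and its nitrogen are therefore not needed for a value of this order in this series, though nothing available accounts for the step itself.

Going by these compounds, it remains open whether the same holds for an unsubstituted phenyl, a 3-methoxyphenyl or a pyridine ring at this place, and whether the chlorine matters at all. Compound 1 gives < 50200 nM, which is a limit of the assay and not a number, and as it differs from compound 2 in more than one place, it does not settle these questions.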